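Sulfonylation of the terminal amine in a spiro series

The compounds below may be only part of what the source reports. "The series", "measured", "known", "first", "only" and "open" are said of these compounds alone.

Measured so far in an assay on HEK293 cells for displacement of a labelled ligand from NPC1-like intracellular cholesterol transporter 1 (Homo sapiens); a lower number here means a stronger inhibitor, a higher number a weaker inhibitor:
compound 1 `CC(C)(C)c1ccc(C(=O)N2CCC3(CC2)C(=O)N(CC(=O)NCCC(=O)O)CN3c2ccccc2)cc1`, 11400 nM
compound 2 `CS(=O)(=O)NCCCNC(=O)CN1CN(c2ccccc2)C2(CCN(C(=O)c3ccc(C4CCCCC4)cc3)CC2)C1=O`, 3800 nM
compound 3 `CC(C)(C)c1ccc(C(=O)N2CCC3(CC2)C(=O)N(CC(=O)NCCCN)CN3c2ccccc2)cc1`, 4200 nM

Compound 3 stands second highest of the three numbers in this assay; compound 2 is nearest, within the scatter of it, and compound 1 furthest, beyond the scatter. Going by the values given here, the one measured step, a 2.7-fold lower number from compound 1 to compound 3 (0.43 log units; beyond the scatter), is a modest one and concerns the end of the chain.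

Compound 4 `CC(C)(C)c1ccc(C(=O)N2CCC3(CC2)C(=O)N(CC(=O)NCCCNS(C)(=O)=O)CN3c2ccccc2)cc1` differs from compound 3 by methylsulfonyl in place of hydrogen on an amine nitrogen. Among the compounds with values here, no measured step carries this same change. What bears on it is compound 2, which carries the same methanesulfonamido chain as compound 4 and differs from it only in the aryl substituent; compound 2 gives 3800 nM, within the scatter of compound 3. From that, compound 4 is expected to sit near compound 3 and compound 2, and its step of a 1.1-fold lower number from compound 3 to compound 4 (0.02 log units; within the scatter) is estimated to stay within the scatter. Compound 4 is estimated at 4000 nM, with a range of 1500 nM to 10000 nM in this assay.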

Compound 4, half-maximal inhibitory concentration: 10400 nM
Compound 4: middle estimate off by 2.6-fold (0.41 log units), on the low side; measured number outside the range, above it.
By their numbers in this assay, from the lowest: compounds 2 and 3 (each within the scatter of the next); then compounds 4 and 1 (each within the scatter of the next).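

Methylsulfonyl on the amine nitrogen is not a silent change in this assay: it gives a 2.5-fold higher number from compound 3 to compound 4 (0.39 log units; beyond the scatter) and so separates the amine end from the sulfonylated one. The sulfonylated end instead reads alike with the carboxy end, as a 1.1-fold lower number from compound 1 to compound 4 (0.04 log units; within the scatter) stays within the scatter, and among these tert-butyl compounds only the free amine stands apart. The closeness of compound 2 to compound 3 therefore did not describe the chain end alone, since with the methanesulfonamido chain held constant the aryl substituent also counts, tert-butyl in place of cyclohexyl giving a 2.7-fold higher number from compound 2 to compound 4 (0.44 log units; beyond the scatter) on this series. No evidence at hand accounts for these steps.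

Open, as far as these compounds go, is how a cyclohexyl compound carrying the free amine end would read, and with it whether methylsulfonyl costs the same on that aryl substituent. Also open, from the compounds shown here alone, is whether an acetyl group on the same nitrogen, or a longer chain, would follow the amine or the methanesulfonamido end.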